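From allyl to butyl at the edge of detection

The compounds below may be only part of what the source reports. "The series", "measured", "known", "first", "only" and "open" are said of these compounds alone.

In a functional assay on CHO-K1 cells (Cricetulus griseus) for inhibition, read by sulforhodamine B assay, with a stated time of 72 h (a lower number here means a stronger inhibitor, a higher number a weaker inhibitor), compound 1 (`C=CCNC(=C\C(=O)/C=C/c1ccc(O)c(OC)c1)/C=C/c1ccc(O)c(OC)c1`) stands at > 25000 nM and that is a limit, not a number. Compound 2 (`COc1cc(/C=C/C(=O)/C=C(/C=C/c2ccc(OC(C)=O)c(OC)c2)NCC(C)C)ccc1OC(C)=O`) also gives > 25000 nM and that too is a limit. Compound 1 therefore offers no exact number to start from (the limit of > 25000 nM in this assay, at which 2 of the 3 values shown sit). Compound 3 (`CCC(C)NC(=C\C(=O)/C=C/c1ccc(O)cc1)/C=C/c1ccc(O)cc1`) does give a measured number, with 15100 nM as its half-maximal inhibitory concentration.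

Compound 4 (`CCCCNC(=C\C(=O)/C=C/c1ccc(O)c(OC)c1)/C=C/c1ccc(O)c(OC)c1`) is compound 1 with allylamino changed to butylamino, which means propyl in place of vinyl on a saturated chain carbon bound to an amine nitrogen. Within the data shown here, no two measured compounds differ in only one place, so no measured step shows how large such a change tends to be.

A small step of an at least 1.1-fold lower number from compound 1 to compound 4 (0.05 log units; that floor lies within the scatter) is expected, within the usual scatter or slightly towards a stronger inhibitor. A measured number remains possible, as compound 3 shows with 15100 nM in this assay here. Another limit would be no surprise, however. For compound 4 the estimated value is 22000 nM with an expected range from 10000 nM to 40000 nM in this measurement.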

Compound 4, half-maximal inhibitory concentration: 20400 nM
For compound 4 the middle estimate is 1.1-fold (0.03 log units) above the measured one; the measured number falls inside the stated range.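

Among these compounds, compound 4 gives 20400 nM, so with butylamino in this place the core of compound 1 yields a measured number in this assay, which none of the earlier compounds on exactly this core had provided. Compound 1 stays at > 25000 nM, which is a limit and not a number. Read against that limit, the change of vinyl to propyl on a saturated chain carbon bound to an amine nitrogen is an at least 1.2-fold lower number from compound 1 to compound 4 (0.08 log units; that floor lies within the scatter), and the true step may be larger than this floor, which is all that can be stated here: the limit of > 25000 nM in this assay, at which 2 of the 4 values shown sit.

Still open, going by these compounds, is whether the saturation of the chain or its length matters more: a propylamino group on the same core would separate the two, since it would keep the length of allylamino while removing its double bond. On these data alone, it is also open whether a longer chain such as hexylamino, or a ring such as cyclohexylamino, would bring the number clearly down from that of compound 4.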